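The compounds below may be only part of what the source reports. "The series", "measured", "known", "first", "only" and "open" are said of these compounds alone.

Compound 1 `COc1ccc(C(=O)NNc2c(Br)cccc2Br)cc1`: > 100000 nM
Compound 2 `CCOc1ccc(C(=O)NNc2c(Br)cccc2Br)cc1`: > 100000 nM
Compound 3 `CC(C)(C)c1ccc(C(=O)NNc2c(Br)cccc2Br)cc1`: > 100000 nM

These three compounds, which share a core, were tested in a toxicity assay on MDCK cells (Canis lupus familiaris) for cytotoxicity, read by CCK-8 assay, with a stated time of 48 h; a higher number here means that more compound is tolerated, a lower number that less compound is tolerated. Each entry is a limit of the assay and not a number, and the series is uniform on this point: the limit of > 100000 nM in this assay, at which 3 of the 3 values shown sit. Compound 2 therefore has no exact position among the others, and its > 100000 nM is a limit.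

Compound 4 `O=C(NNc1c(Br)cccc1Br)c1ccc(F)cc1` has not yet been measured. It carries fluoro in place of ethoxy on an aromatic carbon, para to a large group: fluoro in place of ethoxy on an aromatic carbon.

The closest measured changes are at that same aromatic carbon: a step that the two limits leave unreadable from compound 1 to compound 3, and a step that the two limits leave unreadable from compound 2 to compound 3. A third change lies within the ethoxy group itself: a step that the two limits leave unreadable from compound 1 to compound 2. None of these gives a size to carry over. Methoxy, ethoxy and tert-butyl all leave compounds 1, 2 and 3 at the same limit, and none of these compounds goes against that. Fluoro has not been tested in this series, so the expectation is an extrapolation.

No step beyond the scatter is expected in this assay, and no direction is favoured. The expected change is a step that the limit leaves unreadable from compound 2 to compound 4. For compound 4 the estimated value is 130000 nM, with an expected range of 60000 nM to 300000 nM.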

Compound 4, half-maximal cytotoxic concentration: > 100000 nM
Compound 4 ended at the assay's limit (the forecaster's own chance of this, stated with the estimate: 75%); the middle value is on the limit's open side.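

Compound 4, like compounds 1, 2 and 3, gives no readable step to any of the others, and no step among the four can be read: the limit of > 100000 nM in this assay, at which 4 of the 4 values shown sit.

The compounds shown leave open how much compound each of the four tolerates beyond that limit, and whether any group on this aromatic carbon would give a measurable value in this assay.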